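This account rests on a few compounds, and the source may have more. Where it says the series, first, only, none or still open, it means among the compounds named here.

Measured in an ADME assay on microsomes from liver (Homo sapiens) for pharmacokinetics, read by LC-MS, using NADPH, with a stated time of 45 min, tested at 1 uM; on this read-out higher numbers stand for fast clearance and lower numbers for slow clearance:
- compound 1 `COc1cc(OCc2ccnc(N)n2)cc2sc(N[C@H]3CCCC[C@@H]3O)nc12`: 9.5 mL/min/kg
- compound 2 `COc1cc(OCc2ccnc(Nc3ccn(C)n3)n2)cc2sc(N[C@H]3CCCC[C@@H]3O)nc12`: 17 mL/min/kg

For the measured compounds named here, only these two compounds have numbers so far, and they cannot be told apart: the step between them reads a 1.8-fold higher number from compound 1 to compound 2 (0.25 log units; within the scatter). Compound 2, at 17 mL/min/kg, therefore stands within the scatter of compound 1.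

The next compound is compound 3 `COc1cc(OCc2ccnc(Nc3cn[nH]c3)n2)cc2sc(N[C@H]3CCCC[C@@H]3O)nc12`, which differs from compound 2 as follows: 1H-pyrazol-4-yl in place of 1-methyl-1H-pyrazol-3-yl on a nitrogen on an aromatic ring. Here 1H-pyrazol-4-yl takes the place of 1-methyl-1H-pyrazol-3-yl on a nitrogen on an aromatic ring. Going by the values given here, one measured step bears on this, the one that placed 1-methyl-1H-pyrazol-3-yl on that nitrogen in place of hydrogen: a 1.8-fold higher number from compound 1 to compound 2 (0.25 log units; within the scatter). Among the compounds with values here, no measured compound carries 1H-pyrazol-4-yl, and no measured step exchanges one such group for another, so the support is thin. With that single step inside the scatter, no change beyond the scatter is expected in this assay, and no direction is favoured. The expected step is a 1.2-fold lower number from compound 2 to compound 3 (0.08 log units; within the scatter). For compound 3 the estimated value is 14 mL/min/kg, with an expected range of 7.5 mL/min/kg to 26 mL/min/kg.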

Compound 3, clearance: 32 mL/min/kg
The estimate for compound 3 lay 2.3-fold (0.36 log units) below the measured number; measured number above the stated range.
By their numbers in this assay, from the lowest: compounds 1, 2 and 3 (each within the scatter of the next, the first and the last beyond it).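

In this assay, for the compounds shown here, a group on this nitrogen now gives a step beyond the scatter for the first time: placing 1H-pyrazol-4-yl there in place of hydrogen gives a 3.4-fold higher number from compound 1 to compound 3 (0.53 log units; beyond the scatter), a modest step, whereas 1-methyl-1H-pyrazol-3-yl had stayed within the scatter of compound 1. The direct exchange of the two pyrazole groups gives a 1.9-fold higher number from compound 2 to compound 3 (0.27 log units; within the scatter), so compound 2 and compound 3 cannot be told apart, and only compound 1 and compound 3 are separated in this short series. Nothing available explains the step to compound 3.

Compound 3 differs from compound 2 both in lacking the methyl group and in how the pyrazole ring is attached, and the compounds shown do not separate these two features, which a 1-methyl-1H-pyrazol-4-yl or a 1H-pyrazol-3-yl group on this nitrogen could begin to do. Also open, as far as these compounds go, is whether a six-membered ring such as pyridin-3-yl, or a small group such as acetyl, on the same nitrogen would stay within the scatter of compound 1.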